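Extending the Alkoxy Group: Methoxy to Isopropoxy

The source may hold more compounds than are shown below. What is called first, only, known or untested is meant among the compounds shown, and "the series" means these compounds.

Compound 1, `COc1cccc(OC)c1OCCNCCOc1ccccc1OCc1ccccc1`: 26900 nM
Compound 2, `COc1cccc(OC)c1OCCNCCOc1ccccc1OCc1ccccc1C`: 11500 nM
Compound 3, `COc1ccc(COc2ccccc2OCCNCCOc2c(OC)cccc2OC)cc1`: 8500 nM

Three compounds share one core and differ in a single substituent. In a functional assay on PC-3 cells (Homo sapiens) for cytotoxicity, read by sulforhodamine B assay (a higher number here means a weaker inhibitor of growth, a lower number a stronger inhibitor of growth), compound 1 gives 26900 nM. Compound 2 gives 11500 nM, and compound 3 gives 8500 nM. Compound 3 has the lowest number of the three: its gap to compound 1, a 3.2-fold lower number from compound 1 to compound 3 (0.50 log units; beyond the scatter), lies beyond the scatter, whereas its gap to compound 2, a 1.4-fold lower number from compound 2 to compound 3 (0.13 log units; within the scatter), lies within it, so no order between compound 2 and compound 3 can be claimed. Compound 4, `COc1cccc(OC)c1OCCNCCOc1ccccc1OCc1ccc(OC(C)C)cc1`, carries isopropyl in place of methyl on an oxygen on an aromatic ring. Going by the values given here, no measured step is of this exact kind; the steps that bear on it are a 2.3-fold lower number from compound 1 to compound 2 (0.37 log units; beyond the scatter) and a 3.2-fold lower number from compound 1 to compound 3 (0.50 log units; beyond the scatter), both modest decreases when a group is added on an aromatic carbon. Enlarging the group on the oxygen is therefore expected to lower the number in this assay only modestly, if at all, with an expected step of a 1.4-fold lower number from compound 3 to compound 4 (0.15 log units; within the scatter). Compound 4 is estimated at 6000 nM, with a range from 2500 nM to 15000 nM.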

Compound 4, concentration for 50% growth inhibition: 2000 nM
Compound 4: middle estimate off by 3.0-fold (0.48 log units), on the high side; the measured number lies below the stated range.
By their numbers in this assay, from the lowest: compound 4; then compounds 3 and 2 (each within the scatter of the next); then compound 1.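

Enlarging the group on the oxygen from methoxy to isopropoxy, on the same 4-substituted benzyl arm, matters in this assay (a 4.3-fold lower number from compound 3 to compound 4 (0.63 log units; beyond the scatter)), whereas the earlier substituents on this arm left compound 2 and compound 3 within the scatter of each other. Compound 4 alone separates from that pair (a 5.8-fold lower number from compound 2 to compound 4 (0.76 log units; beyond the scatter)), and its step from the unsubstituted parent (a 13-fold lower number from compound 1 to compound 4 (1.13 log units; beyond the scatter)) is the only large one in the series, so compound 4 has the lowest number of the four, beyond the scatter of every other compound. No measurement offered here accounts for this gain.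

The compounds shown leave open whether ethoxy would fall between methoxy and isopropoxy, and whether a tert-butoxy group or a longer chain such as hexyloxy would lower the number further. They also leave open whether the oxygen itself is needed, which a dimethylamino group in its place would test.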